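The source may report more compounds than this note shows. Statements on the series, on what has been measured and on what is new or still open speak of the compounds shown alone.

Working notes on the series.

Of the compounds shown here, two of the shared core have been measured. Compound 1 `CC1CCN(c2c(S(=O)(=O)c3ccc(F)c(F)c3)cnc3c(F)cccc23)CC1` and compound 2 `CC1CCN(c2c(S(=O)(=O)c3cccc(C#N)c3)cnc3ccc(F)cc23)CC1` were both run in an assay on isolated protein for displacement of a labelled ligand from metabotropic glutamate receptor 5 (Homo sapiens), with a stated time of 60 min, tested at 1 uM; on this read-out lower numbers stand for less inhibition and higher numbers for more inhibition at the one concentration tested (going by the name of the read-out). In this assay compound 1 gives 93%, and compound 2 gives 93%. On these numbers compound 1 stands level with compound 2 at the digits shown; the two values sit within the usual scatter of each other, so no order between them can be read from the data. Both sit near the top of the read-out range.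

Compound 3 `CC1CCN(c2c(S(=O)(=O)c3cccc(F)c3)cnc3c(F)cccc23)CC1` has not yet been measured in this assay. It differs from compound 1 in one place: hydrogen in place of fluoro on an aromatic carbon. Among the compounds with values here, no step between measured compounds that differ in a single place is available, so the size of this change cannot be taken from a precedent. Given that compound 1 gives 93% and so sits near the top of the read-out range at the one concentration tested, the step from compound 1 to compound 3 is expected to be small, most likely none beyond the scatter, with any movement more likely downward than upward simply because compound 1 gives 93% and leaves little room above that number.

Compound 3 is therefore estimated at 90%, with a range from 76% to 98%, which corresponds to an expected step of a number 3 percentage points lower from compound 1 to compound 3 (within the scatter) from compound 1 to compound 3 in this assay.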

Compound 3, a percentage reported as inhibition, at one concentration (the size of the read-out at that concentration, not a potency): 62%
Beside the measured number, compound 3's estimate is 28 percentage points above it, and the stated range ends above it.
By their numbers in this assay, from the lowest: compound 3; then compounds 1 and 2 (each within the scatter of the next).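

The first step read at a single place in the series puts hydrogen in place of fluoro on an aromatic carbon, ortho to a fluoro group and para to a large group, and in this assay it gives a number 31 percentage points lower from compound 1 to compound 3 (beyond the scatter) on going from 3,4-difluorophenyl to 3-fluorophenyl. Within the data shown here, this position is therefore not indifferent to the change: one fluorine atom, with no ring, hydrogen-bond donor, hydrogen-bond acceptor or net charge entering or leaving, separates a reading near the top of the range from a clearly lower one, which the two level values of the earlier compounds could not show. Nothing measured on these compounds accounts for the size of this step.

As far as these compounds go, whether chloro, methyl or methoxy on the same aromatic carbon would hold the reading of compound 1 or fall with compound 3 remains open, so it cannot yet be said whether fluoro itself is needed there or only some group other than hydrogen. Also open, from the compounds shown here alone, is whether the step keeps its size with the other fluoro group of the 3,4-difluorophenyl replaced by a nitrile or an amine, or with a different substitution on the shared core.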